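A few compounds are considered here, and "the series" means these few. Any claim that something is new, unique, unknown or untested is made for them only; others in the source may bear on it.

Compound 1 `CCCn1c(=O)[nH]c2nc(-c3ccc(S(=O)(=O)N4CCN(c5ccccc5C)CC4)cc3)[nH]c2c1=O` is the measured reference of this small set. In an assay on CHO cells for displacement of a labelled ligand from adenosine receptor A1 (Homo sapiens), read by scintillation counting, with a stated time of 90 min, in the presence of a further agent that is not named here (on this read-out higher numbers stand for weaker inhibition and lower numbers for stronger inhibition), compound 1 gives 419 nM. Compound 2 `CCCn1c(=O)[nH]c2nc(-c3ccc(S(=O)(=O)N4CCN(c5ccccc5Br)CC4)cc3)[nH]c2c1=O` carries bromo in place of methyl on an aromatic carbon. In this assay compound 2 is reported as > 1000 nM, which is a limit of the assay and not a number. That single change brings an at least 2.3-fold higher number from compound 1 to compound 2 (0.37 log units; beyond the scatter), so compound 2 stands at the weak end of what has been measured here, without an exact figure of its own.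

Compound 3 `CCCn1c(=O)[nH]c2nc(-c3ccc(S(=O)(=O)N4CCN(Cc5ccc(Br)c(F)c5)CC4)cc3)[nH]c2c1=O` is not yet measured. It differs from compound 2 by 4-bromo-3-fluorobenzyl in place of 2-bromophenyl on an amine nitrogen in a ring. Among the measured compounds shown here, the one measured step, an at least 2.3-fold higher number from compound 1 to compound 2 (0.37 log units; beyond the scatter), swapped a small group on the ring while keeping the ring itself, and so does not speak directly to replacing the whole ring with a benzyl group carrying two different halogens. For the measured compounds named here, no measured step bears on this change, and the expectation must rest on where compound 2 already stands. The estimate for compound 3 therefore amounts to a step that the limit leaves unreadable from compound 2 to compound 3, no more than a guess near the limit. Compound 3 is expected to give about 1500 nM, within a range from 400 nM to 6000 nM.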

Compound 3, inhibition constant: 326 nM
Compound 3: middle estimate off by 4.6-fold (0.66 log units), on the high side; the measured number lies below the stated range.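

Among the compounds shown here, on the amine nitrogen in the ring, a bromine-bearing group does not have to cost binding: in this assay, 4-bromo-3-fluorobenzyl in place of 2-bromophenyl gives an at least 3.0-fold lower number from compound 2 to compound 3 (0.48 log units; beyond the scatter), the first measured step in this set that replaces the whole group on that nitrogen rather than a small group on its ring. Compound 2 is reported only as a limit, so this step has a floor and no exact size: the limit of > 1000 nM in this assay, at which 1 of the 3 values shown sits. Against the 2-methylphenyl of the reference, the same benzyl group gives a 1.3-fold lower number from compound 1 to compound 3 (0.11 log units; within the scatter), so compound 1 and compound 3 stand level, and this nitrogen accepts a benzyl group with two halogens, 9 heavy atoms in all, as well as it accepts that smaller aryl group.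

The change alters several things at once, and these compounds cannot separate the effect of the added carbon of the benzyl group from that of the fluorine or of where the bromine sits. An unsubstituted benzyl, a 4-bromobenzyl or a longer chain such as phenethyl on this nitrogen would each remain to be compared, as would an amine or a carboxylic acid on the aromatic ring.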